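The compounds below may be only part of what the source reports. "The series", "measured", "known", "first", "only" and "open" are said of these compounds alone.

Measured so far in a functional assay on cells (leukaemia cell line, Homo sapiens) for inhibition, read by sulforhodamine B assay, with a stated time of 48 h; a lower number here means a stronger inhibitor of growth, a higher number a weaker inhibitor of growth:
compound 1 `O=S(=O)(Nc1ccc(F)cc1F)c1ccc(-c2cnc(C3CC3)o2)cc1` gives 356 nM
compound 2 `O=S(=O)(Nc1ccc(I)c(Cl)c1)c1ccc(-c2cnc(C3CC3)o2)cc1` gives 1010 nM

Compound 1 has the lower of the two numbers. Compound 3 `Cc1cc(Cl)cc(NS(=O)(=O)c2ccc(-c3cnc(C4CC4)o3)cc2)c1` carries 3-chloro-5-methylphenyl in place of 2,4-difluorophenyl on a sulfonamide nitrogen, a change counted as 3-chloro-5-methylphenyl in place of 2,4-difluorophenyl on a sulfonamide nitrogen with the shared core kept. Among the compounds with values here, the one measured step bearing on this replaces the same 2,4-difluorophenyl, and a 2.8-fold higher number from compound 1 to compound 2 (0.45 log units; beyond the scatter) is modest. A step of similar size towards a higher number is therefore expected in this assay on this single precedent. The expected change is a 2.2-fold higher number from compound 1 to compound 3 (0.35 log units; beyond the scatter) by this estimate. Compound 3 is estimated at 800 nM with an expected range from 300 nM to 2200 nM in this read-out.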

Compound 3, concentration for 50% growth inhibition: 175 nM
Compound 3: the middle estimate sits 4.6-fold (0.66 log units) above what was measured; measured number below the stated range.
By their numbers in this assay, from the lowest: compound 3; then compound 1; then compound 2.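

In this assay, within the data shown here, leaving 2,4-difluorophenyl on the sulfonamide nitrogen need not cost activity: 3-chloro-5-methylphenyl gives a 2.0-fold lower number from compound 1 to compound 3 (0.31 log units; beyond the scatter), the opposite direction to the only earlier step at this place. Two chlorine-bearing phenyl groups also differ widely here, with 3-chloro-5-methylphenyl in place of 3-chloro-4-iodophenyl giving a 5.8-fold lower number from compound 2 to compound 3 (0.76 log units; beyond the scatter), so chlorine alone does not set the number. No supporting data bear on why either step runs as it does.

Whether the methyl or the chlorine of compound 3 accounts for its lower number stays open. So does the outcome with an amine or a carboxylic acid on this phenyl ring.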